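The source may report more compounds than this note shows. Statements on the series, on what has been measured and on what is new or still open speak of the compounds shown alone.

Measured compounds, with their values in a functional assay on SH-SY5Y cells (Homo sapiens) for cytotoxicity, read by MTT assay, with a stated time of 48 h; a higher number here means a weaker inhibitor, a lower number a stronger inhibitor:

compound 1, `[O-][S+](CCC(F)(Cl)C(F)(F)Cl)c1nc2ccccc2s1`, 41500 nM
compound 2, `O=S(=O)(CCC(F)(Cl)C(F)(F)Cl)c1nc2ccccc2s1`, 4500 nM
compound 3, `O=S(=O)(CCC(F)(Cl)C(F)(F)Cl)c1nc2ccc(Cl)cc2s1`, 6000 nM

Compound 1 gives the highest number of the three. Compound 2 and compound 3 each give a lower number than compound 1, and the gap in each case is beyond the usual scatter. Compound 2 and compound 3 lie within the scatter of each other, so no order is drawn between them. How the core of compound 1 differs from the core of compound 2 is not broken down here.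

Going by the values given here, the one change that is measured is chloro in place of hydrogen on an aromatic carbon, which gives a 1.3-fold higher number from compound 2 to compound 3 (0.12 log units; within the scatter) in this assay.

Compound 4, `[O-][S+](CCC(F)(Cl)C(F)(F)Cl)c1nc2ccc(Cl)cc2s1`, is not yet measured. It differs from compound 1 by chloro in place of hydrogen on an aromatic carbon. Among the compounds with values here, the place of the entering chloro is described in the same words for both pairs, so this is the same change as the one made from compound 2 to compound 3.

The expectation for compound 4 rests on that one measured step: because a 1.3-fold higher number from compound 2 to compound 3 (0.12 log units; within the scatter) lies within the scatter, the step of a 1.3-fold higher number from compound 1 to compound 4 (0.10 log units; within the scatter) is expected to be of a similar small size. Within the data shown here, compound 4 is therefore estimated to give about 52000 nM in this assay, with a range from 24000 nM to 110000 nM, given that only one instance of this change is known and it is read against a higher starting number.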

Compound 4, half-maximal inhibitory concentration: 2100 nM
For compound 4 the middle estimate is 25-fold (1.39 log units) above the measured one, outside the stated range (below it).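

Moving chloro in place of hydrogen on an aromatic carbon onto the core of compound 1 gives a 20-fold lower number from compound 1 to compound 4 (1.30 log units; beyond the scatter) in this assay, so the near-silent result on the other core does not carry over to this one. The change therefore cannot be treated as transferable between these two cores, and its size here depends on which core receives it: the same change on two cores in this assay, a 1.3-fold higher number (0.12 log units; within the scatter) from compound 2 to compound 3 and a 20-fold lower number (1.30 log units; beyond the scatter) from compound 1 to compound 4, 26-fold (1.42 log units) apart, beyond the scatter of two such steps

Going by these compounds alone, this rests on only one matched pair per core and shows a difference in outcome, not its origin, so it supports no general rule for the series and gives no way to predict the size of the step on a further core.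

The compounds shown leave open whether another group entering at the same aromatic carbon, such as fluoro, methoxy or an amine, would also behave differently on the two cores, and whether chloro would do so at another place on the six-membered aromatic ring. They also leave open whether the gap between the two cores persists when the halogenated side chain is replaced, for example by a longer chain or by one carrying a carboxylic acid.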